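A few compounds are considered here, and "the series" means these few. Any claim that something is new, unique, unknown or untested is made for them only; others in the source may bear on it.

Working notes on the series, read in a functional assay on the whole organism (Ear) for inhibition, with Mus musculus as the target, with a stated time of 30 min, at a dose of 100 mg/kg by the intraperitoneal route; a lower number here means less inhibition, a higher number more inhibition at the dose given (going by the name of the read-out).

Among the compounds with values here, compound 1 `Cc1ccc(C(=O)/C=C/c2ccc(/C=N/NC(=O)c3ccccc3)cc2)c(C)c1` gives 0.18% in this assay, the lower of the two numbers measured so far. Compound 2 `Cc1ccc(C(=O)/C=C/c2ccc(/C=N/NC(=N)N)cc2)cc1` gives 77.7% in this assay, a number far above that of compound 1 and beyond the usual scatter. Within the data shown here, no step between these two compounds is counted here, since they differ in more than one place; only the two values themselves are noted.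

Compound 3 `Cc1ccc(C(=O)/C=C/c2ccc(/C=N/NC(=N)N)cc2)c(C)c1` has not yet been measured in this assay. It differs from compound 1 in one place: a group of 3 heavy atoms (1 carbon, 2 nitrogen; no ring) in place of a group of 8 heavy atoms (7 carbon, 1 oxygen; one six-membered aromatic ring of carbon only), on an amine nitrogen The group that enters in compound 3 is the same group of 3 heavy atoms (1 carbon, 2 nitrogen; no ring) that compound 2 carries on its amine nitrogen.

For compound 3 a large upward step is expected, a number 69.8 percentage points higher from compound 1 to compound 3 (beyond the scatter), because compound 2 with the same entering group gives 77.7% in this assay. Compound 3 is therefore expected to give about 70% in this assay, within a range of 45% to 92%.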

Compound 3, a percentage reported as inhibition, in the whole organism at one dose (the size of the read-out at that dose, not a potency): 64.2%
Estimate against measurement, compound 3: 5.8 percentage points above; the measured number falls inside the stated range.
By their numbers in this assay, from the lowest: compound 1; then compound 3; then compound 2.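

In this assay, the exchange of benzoyl for the group of 3 heavy atoms on the amine nitrogen can now be read as a change in one place on a shared core, with a number 64 percentage points higher from compound 1 to compound 3 (beyond the scatter). The second change in one place, methyl in place of hydrogen on an aromatic carbon, gives a number 13.5 percentage points lower from compound 2 to compound 3 (beyond the scatter), so this position also affects the read-out, though by a much smaller step than the change on the amine nitrogen. No measurement at hand bears on the reason for either step.

Open, going by these compounds, is whether the methyl step would hold with benzoyl on the amine nitrogen. Also open, on these data alone, is how an acetyl group on that nitrogen, or an ethyl group or a chlorine atom in place of that methyl, would read in this assay.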